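Lengthening the Chain in a Sulfonylurea Series

The source may report more compounds than this note shows. Statements on the series, on what has been measured and on what is new or still open speak of the compounds shown alone.

compound 1 `CCNC(=O)Nc1ccc(S(=O)(=O)Nc2ccccc2C)cc1` — > 200000 nM
compound 2 `CCNC(=O)Nc1ccc(S(=O)(=O)Nc2ccccc2CC)cc1` — 86000 nM

In a functional assay on HT-29 cells (Homo sapiens) for cytotoxicity, read by sulforhodamine B assay, with a stated time of 48 h (on this read-out lower numbers stand for stronger inhibition and higher numbers for weaker inhibition), compound 1 gives > 200000 nM, which is a limit of the assay and not a number. In this assay compound 2 gives 86000 nM. That value is the only number shown in this assay; the other value sits at the limit of > 200000 nM in this assay, at which 1 of the 2 values shown sits. Going by the values given here, the step of an at least 2.3-fold lower number from compound 1 to compound 2 (0.36 log units; beyond the scatter) is the single measured step in this set.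

Compound 3 `CCCc1ccccc1NS(=O)(=O)c1ccc(NC(=O)NCC)cc1` carries the same kind of change one bond further out: methyl in place of hydrogen on a saturated chain carbon, two bonds along the chain from an aromatic carbon, so that ethyl becomes propyl. Among the compounds with values here, the only step that bears on it is an at least 2.3-fold lower number from compound 1 to compound 2 (0.36 log units; beyond the scatter), which was at least modest and toward stronger inhibition. A step in the same direction, of smaller or similar size and not certainly beyond the scatter, is therefore expected, a 1.7-fold lower number from compound 2 to compound 3 (0.24 log units; within the scatter). Compound 3 is estimated at 50000 nM, with a range from 20000 nM to 150000 nM.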

Compound 3, half-maximal inhibitory concentration: 32000 nM
Compound 3: the middle estimate sits 1.6-fold (0.19 log units) above what was measured, within the range that was stated.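

In this assay, going by these compounds alone, the lowering of the number did not stop at ethyl: propyl takes it further, with a 2.7-fold lower number from compound 2 to compound 3 (0.43 log units; beyond the scatter) as the first step read between two actual numbers. Taken whole, the change from methyl to propyl gives an at least 6.2-fold lower number from compound 1 to compound 3 (0.79 log units; beyond the scatter) across the series, so the three compounds fall in one order as the chain grows, with none going against it. The full size of that span stays unfixed, since compound 1 gives a limit of the assay and not a number: the limit of > 200000 nM in this assay, at which 1 of the 3 values shown sits.

On these data alone, whether the trend carries on to a butyl or longer chain or turns back at some length remains open. Also open, as far as these compounds go, is how a branched chain such as isopropyl, or a methoxy group, would compare at this place on the shared core.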